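The source may report more compounds than this note shows. Statements on the series, on what has been measured and on what is new or still open speak of the compounds shown alone.

Of the compounds shown here, three that share one core have been measured in an ADME assay on the whole organism (strain Sprague-Dawley) for pharmacokinetics, with Rattus norvegicus as the target, read by LC-MS, at a dose of 25 mg/kg by the oral route; on this read-out higher numbers stand for higher exposure at the dose given and lower numbers for lower exposure. Compound 1 `C=CC(=O)N1CC[C@H](N2C(=O)N(Cc3ccccc3)Cc3cnc(Nc4ccc(N5CCN(C)CC5)cc4OC)nc32)C1` gives 175 nM, compound 2 `C=CC(=O)N1CC[C@H](N2C(=O)N(c3ccccc3)Cc3cnc(Nc4cccc(N5CCN(C)CC5)c4)nc32)C1` gives 540 nM, and compound 3 `C=CC(=O)N1CC[C@H](N2C(=O)N(c3ccccc3)Cc3cnc(Nc4ccc(N5CCN(C)CC5)c(C)c4)nc32)C1` gives 1880 nM. Compound 2 stands second highest of the three: compound 1 lies beyond the scatter below it, and compound 3 lies beyond the scatter above it. Compound 4 `C=CC(=O)N1CC[C@H](N2C(=O)N(c3ccccc3)Cc3cnc(Nc4ccccc4)nc32)C1` has not yet been measured. It differs from compound 2 in one place: hydrogen in place of 4-methylpiperazin-1-yl on an aromatic carbon. For the measured compounds named here, no measured pair shows this same change, so its effect cannot be read from the numbers at hand. A somewhat lower exposure is expected, and the step of a 2.2-fold lower number from compound 2 to compound 4 (0.33 log units; beyond the scatter) is estimated to reach beyond the scatter. For compound 4 the expected value in this assay is 250 nM, within a range from 50 nM to 1300 nM.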

Compound 4, maximal plasma concentration: 3800 nM
Compound 4: the middle estimate sits 15-fold (1.18 log units) below what was measured; the whole stated range lies below it.
By their numbers in this assay, from the lowest: compound 1; then compound 2; then compound 3; then compound 4.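

In this assay, replacing the 4-methylpiperazin-1-yl group with hydrogen on this aromatic carbon gives a 7.0-fold higher number from compound 2 to compound 4 (0.85 log units; beyond the scatter). At this position, then, the large ring is not needed for high oral exposure in the rat, and exposure is higher without it. No information at hand explains the rise. As far as these compounds go, whether a morpholine ring or a small dimethylamino group at this carbon would give exposure closer to compound 2 or compound 4 remains open. So does whether the same swap would have a similar effect on a different core.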